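The compounds below may be only part of what the source reports. "The series", "measured", "known", "first", "only" and "open" are said of these compounds alone.

In a physicochemical assay for lipophilicity, read by HPLC, using the shake flask method (on this read-out lower numbers stand for lower lipophilicity and higher numbers for higher lipophilicity), compound 1 `CCC/C(=N\C#N)N(C)Cc1ccc(Cl)nc1` gives 1.55. Compound 2 `C/C(=N\C#N)N(Cc1ccc(Cl)nc1)C(C)C` gives 1.46, within the usual scatter of compound 1, so these two cannot be told apart. Compound 3 `CCCCN(Cc1ccc(Cl)nc1)/C(C)=N/C#N` gives 2.13, beyond the scatter of both and the highest number of the three.

Compound 4 `CC/C(=N\C#N)N(C)Cc1ccc(Cl)nc1` has not yet been measured. Its structure departs from compound 1 by hydrogen in place of methyl on a saturated chain carbon, two bonds along the chain from a carbon with a double bond to nitrogen, which reads as propyl to ethyl on the shared core.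

Among the compounds with values here, only one measured step offers guidance: a number 0.67 log units higher from compound 2 to compound 3 (beyond the scatter), with butyl in place of isopropyl on an amine nitrogen. Within the data shown here, that step lies at a different place, so it is a rough guide only, and no measured step shortens a chain at this position. A somewhat smaller step downward is nevertheless expected, probably just beyond the scatter. The expected size is a number 0.40 log units lower from compound 1 to compound 4 (beyond the scatter). Compound 4 is therefore estimated at 1.15, with an expected range of 0.9 to 1.4.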

Compound 4, partition coefficient: 1.12
Compound 4: the middle estimate sits 0.03 log units above what was measured, and the stated range covers the measured number.
By their numbers in this assay, from the lowest: compound 4; then compounds 2 and 1 (each within the scatter of the next); then compound 3.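

In this assay this position now has a measured step of its own: with propyl to ethyl on the shared core, the read-out gives a number 0.43 log units lower from compound 1 to compound 4 (beyond the scatter). Within the data shown here, the only earlier step lay on an amine nitrogen, so it could not show that the chain on this carbon affects the number; the new step shows that the loss of a single carbon here is enough to carry the read-out beyond the scatter. Nothing available gives a cause for this step. From the compounds shown here alone, whether the trend continues along the series remains open: a methyl in place of the ethyl of compound 4 could extend the fall, and a butyl in place of the propyl of compound 1 could reverse it. Also open, going by these compounds, is how an amine or a hydroxyl on this chain would shift the number.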